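Butylsulfonyl for Isopropylcarbonyl: What Happens to Half-Life?

A few compounds are considered here, and "the series" means these few. Any claim that something is new, unique, unknown or untested is made for them only; others in the source may bear on it.

Of the compounds shown here, three have been measured so far in an ADME assay on the whole organism (strain Swiss Webster) for metabolic stability, with Mus musculus as the target, using cassette dosing, at a dose of 0.3 mg/kg by the oral route; on this read-out lower numbers stand for a shorter-lived compound and higher numbers for a longer-lived compound. Compound 1 (`CCC(C)C(=O)N1CCC(NC(=O)Nc2ccc(C(C)C)cc2)CC1`) gives 2 h, and compound 2 (`CCC(C)C(=O)N1CCC(NC(=O)NC2CCCCCC2)CC1`) gives 8.4 h. Compound 3 (`CC(C)C(=O)N1CCC(NC(=O)Nc2ccc(OC(F)(F)F)cc2)CC1`) gives 9 h, the highest of the three numbers on paper. Among the measured compounds shown here, that value lies within the usual scatter of the one for compound 2, so those two cannot be told apart, while the gap down to compound 1 lies beyond the scatter.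

Compound 4 (`CCCCS(=O)(=O)N1CCC(NC(=O)Nc2ccc(OC(F)(F)F)cc2)CC1`) has not yet been measured. It carries butylsulfonyl in place of isopropylcarbonyl on an amine nitrogen in a ring. For the measured compounds named here, no two measured compounds differ in one place only, so nothing here shows directly what a single change does in this assay. The best anchor is compound 3 at 9 h, which shares everything with compound 4 except this one group. The low number of compound 1 at 2 h is a reminder that much shorter lives occur among these compounds, so the range must stay wide. The expected change is a 1.5-fold lower number from compound 3 to compound 4 (0.18 log units; within the scatter), a slight shortening that is not expected to go beyond the scatter. Compound 4 is estimated at 6 h, with an expected range of 2.5 h to 13 h.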

Compound 4, half-life in the Mus musculus assay: 2 h
The estimate for compound 4 lay 3.0-fold (0.48 log units) above the measured number; the whole stated range lies above it.
By their numbers in the Mus musculus assay, from the lowest: compounds 1 and 4 (each within the scatter of the next); then compounds 2 and 3 (each within the scatter of the next).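

This is the first change at a single place among the compounds shown, and the answer is clear: in the Mus musculus assay, butylsulfonyl in place of isopropylcarbonyl on the amine nitrogen in the ring gives a 4.5-fold lower number from compound 3 to compound 4 (0.65 log units; beyond the scatter). The group on this nitrogen can therefore move the half-life beyond the scatter by itself, with all the rest of the molecule unchanged. In a physicochemical assay for lipophilicity, using the shake flask method (on this read-out higher numbers stand for higher lipophilicity and lower numbers for lower lipophilicity), compound 3 gives 3.56 and compound 4 gives 4.13. A possible reason for the shorter life is the rise in lipophilicity that comes with the change, as measured in the physicochemical assay: the measured partition coefficient of compound 3, 3.56, and of compound 4, 4.13, a number 0.57 log units higher (beyond the scatter).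

This single step cannot separate the two things that changed together, the sulfonyl link in place of the carbonyl link and the butyl chain in place of the isopropyl group. A methylsulfonyl group or a butylcarbonyl group on the same nitrogen would show which of the two matters more, and whether half-life keeps falling as the partition coefficient rises.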